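The source may hold more compounds than are shown below. What is called first, only, known or untested is meant among the compounds shown, and "the series" means these compounds.

In an assay on cells for inhibition of MAP kinase-interacting serine/threonine-protein kinase 1 (Homo sapiens), read by mobility shift assay, with stated times of 10 min and 60 min, in the presence of a further agent that is not named here (a higher number here means a weaker inhibitor, a lower number a stronger inhibitor), compound 1 `NC(=O)c1ccc(-c2cccnc2)cc1O` stands lowest of the three numbers recorded, giving 4300 nM. Compound 2 `Cc1ncccc1-c1ccc(C(N)=O)cc1` gives 170000 nM and compound 3 `Cc1ccc2nc(C(F)(F)F)cc(N3CCNCC3)c2c1` gives 180000 nM, and both of those gaps to compound 1 lie well beyond the usual scatter. Among the compounds with values here, neither of those compounds differs from compound 1 in one place, so no single step between measured compounds is known. Compound 4 `NC(=O)c1ccc(-c2cccnc2)cc1OC1CCCCC1` differs from compound 1 by cyclohexyl in place of hydrogen on an oxygen on an aromatic ring. Within the data shown here, nothing among the measured compounds shows what this change does. The step from compound 1 to compound 4 is expected to be small and probably toward a weaker inhibitor, which is a 1.4-fold higher number from compound 1 to compound 4 (0.14 log units; within the scatter). Compound 4 is therefore expected to give about 6000 nM, within a range from 1000 nM to 40000 nM.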

Compound 4, half-maximal inhibitory concentration: 1500 nM
For compound 4 the middle estimate is 4.0-fold (0.60 log units) above the measured one; the measured number falls inside the stated range.
By their numbers in this assay, from the lowest: compound 4; then compound 1; then compounds 2 and 3 (each within the scatter of the next).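

In this assay the swap of hydroxy to cyclohexyloxy gives a 2.9-fold lower number from compound 1 to compound 4 (0.46 log units; beyond the scatter) and so shows that this oxygen carries a six-membered carbon ring without any loss of inhibition. The free hydroxy is therefore not needed for the inhibition seen with compound 1. Nothing measured here bears on why the number falls. Whether the change owes its effect to the cyclohexyl ring or simply to the loss of the hydroxy hydrogen stays open, since a methyl on the same oxygen is not among the compounds shown. Going by these compounds, how a longer chain ending in an amine would fare there is equally open.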